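The source may hold more compounds than are shown below. What is called first, only, known or untested is meant among the compounds shown, and "the series" means these compounds.

Of the compounds shown here, three have so far been tested in a functional assay on HCT-116 cells (Homo sapiens) for antiproliferative activity, read by CCK-8 assay, with a stated time of 72 h, tested at 2 uM; a lower number here means a weaker effect, a higher number a stronger effect of the compound at the concentration tested. Compound 1 `CN1CCN(c2nc(Cl)nc3c2ncn3Cc2ccc(C(=O)Nc3ccccc3N)cc2)CC1` gives 71.6% there, the highest of the three numbers. Compound 3 `Nc1ccccc1NC(=O)c1ccc(CNc2nc(Cl)nc3c2ncn3Cc2ccccc2)cc1` gives 7.7% in this assay, and compound 2 `CC(C)n1cnc2c(Nc3cccc(Cl)c3)nc(NCOCc3ccc(C(=O)Nc4ccccc4N)cc3)nc21` gives 7.12%; each of these lies beyond the usual scatter from the number of compound 1, while the two of them lie within the scatter of each other. No pair among these measured compounds differs in a single place, so how much a one-place change moves the number in this assay has not yet been seen.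

The next compound, compound 4 `CC1CCN(c2nc(Cl)nc3c2ncn3Cc2ccc(C(=O)Nc3ccccc3N)cc2)CC1`, differs from compound 1 in one place: 4-methylpiperidin-1-yl in place of 4-methylpiperazin-1-yl on an aromatic carbon. Everything else in the molecule stays as in compound 1.

Among the measured compounds shown here, with no measured one-place step to lean on, the expectation for compound 4 rests on compound 1 alone, whose 71.6% sets the starting point. The change is expected to bring a modest fall in this assay, a number 11.6 percentage points lower from compound 1 to compound 4 (beyond the scatter), possibly no larger than the scatter. Compound 4 is therefore estimated to give 60% in this assay, within a range from 35% to 80%.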

Compound 4, a percentage reported as inhibition, at one concentration (the size of the read-out at that concentration, not a potency): 70.9%
Compound 4: the middle estimate sits 10.9 percentage points below what was measured, and the stated range covers the measured number.
By their numbers in this assay, from the lowest: compounds 2 and 3 (each within the scatter of the next); then compounds 4 and 1 (each within the scatter of the next).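

In this assay, the first one-place step seen at this position is small: a number 0.7 percentage points lower from compound 1 to compound 4 (within the scatter). The swap of 4-methylpiperazin-1-yl for 4-methylpiperidin-1-yl exchanges one ring nitrogen for a carbon while keeping the six-membered ring and the number of heavy atoms, so for this pair that nitrogen is not needed to keep the read-out at the tested concentration. Nothing available here explains why the number holds across this change.

One swap cannot show how much variation this aromatic carbon accepts, and a morpholin-4-yl group with an oxygen in the ring, an open-chain dimethylamino group or a simple unsubstituted amine might give a quite different number. From the compounds shown here alone, the read-out is also the size of an effect at one concentration rather than a potency, so whether compound 1 and compound 4 would still match at other concentrations remains open.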